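Changing the aryl group on sulfur: compound 2 to compound 4

This account rests on a few compounds, and the source may have more. Where it says the series, first, only, none or still open, it means among the compounds named here.

In a functional assay on A-375 cells (Homo sapiens) for inhibition, read by CCK-8 assay, with a stated time of 72 h, tested at 8 uM (a lower number here means less inhibition of growth, a higher number more inhibition of growth at the concentration tested), compound 2 `Nc1ccccc1NC(=O)c1ccc(CSc2cccc(F)c2)cc1` gives 76.3% and compound 1 `CCc1ccc(SCc2ccc(C(=O)Nc3ccccc3N)cc2)cc1` gives 71.1%, two values within the scatter of each other. Compound 3 `Nc1ccccc1NC(=O)/C=C/c1ccc(CSc2ccc(F)cc2)cc1` gives 24.6%, far beyond the scatter below compound 2.

Compound 4 `Nc1ccccc1NC(=O)c1ccc(CSc2ccc(Br)cc2)cc1` is the next compound to be read, and its change from compound 2 is 4-bromophenyl in place of 3-fluorophenyl on a sulfur. Among the compounds with values here, only one measured step involves a group on that sulfur. It is 3-fluorophenyl in place of 4-ethylphenyl, a number 5.2 percentage points higher from compound 1 to compound 2 (within the scatter), and it stays within the scatter. Within the data shown here, no measured compound carries bromine, so this single step is thin support, and the range is kept wide. On that step, no change beyond the scatter is expected. The estimated step is a number 4.3 percentage points lower from compound 2 to compound 4 (within the scatter). For compound 4, the expected value is 72%, with an estimated range of 58% to 84%.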

Compound 4, percent growth inhibition at one concentration: 6.17%
Estimate against measurement, compound 4: 65.8 percentage points above; measured number outside the range, below it.
By their numbers in this assay, from the lowest: compound 4; then compound 3; then compounds 1 and 2 (each within the scatter of the next).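

In this assay, within the data shown here, the aryl group on sulfur proves far less forgiving than the one earlier step on that sulfur suggested: 4-bromophenyl in place of 3-fluorophenyl gives a large loss (a number 70.1 percentage points lower from compound 2 to compound 4 (beyond the scatter)). The loss also appears against the other aryl group, with bromo in place of ethyl on an aromatic carbon (a number 64.9 percentage points lower from compound 1 to compound 4 (beyond the scatter)), so it does not depend on which of these two compounds serves as the reference. Nothing available bears on the reason for this drop.

Since 3-fluorophenyl and 4-bromophenyl differ in both halogen and ring placement, the compounds shown do not separate these two changes. Going by these compounds, a 3-bromophenyl or 4-chlorophenyl group on the shared core would bear on that question, and whether other groups at this place on sulfur keep the inhibition remains open.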